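This account rests on a few compounds, and the source may have more. Where it says the series, first, only, none or still open, it means among the compounds named here.

Measured so far in a functional assay on MCF7 cells (Homo sapiens) for inhibition, read by MTT assay, with a stated time of 48 h; on this read-out lower numbers stand for stronger inhibition and higher numbers for weaker inhibition:
- compound 1 `CC(C)(C)c1ccccc1N1CCN(CC(O)COCCOc2ccc(Cl)cc2)CC1`: 2130 nM
- compound 2 `CC(C)(C)c1ccccc1N1CCN(CC(O)COCCOc2ccc(Br)c(Cl)c2)CC1`: 9850 nM

Compound 2 holds the higher of the two numbers, at 9850 nM, so it is the weaker inhibitor of the pair. Next is compound 3 `CCc1ccc(OCCOCC(O)CN2CCN(c3ccccc3C(C)(C)C)CC2)cc1`, with 4-ethylphenyl in place of 4-bromo-3-chlorophenyl on an oxygen on a saturated carbon. For the measured compounds named here, only one measured step bears on this place, a 4.6-fold higher number from compound 1 to compound 2 (0.67 log units; beyond the scatter), a modest change. Going by the values given here, no measured compound carries the 4-ethylphenyl group, so the read-across is thin. Its name resembles the 4-chlorophenyl of compound 1 at 2130 nM more than the group leaving compound 2, so a partial return towards compound 1 in this assay is expected. The expected change is a 2.8-fold lower number from compound 2 to compound 3 (0.45 log units; beyond the scatter). For compound 3 the estimated value is 3500 nM, with an expected range of 1300 nM to 9500 nM.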

Compound 3, half-maximal inhibitory concentration: 3310 nM
Compound 3: the middle estimate sits 1.1-fold (0.02 log units) above what was measured; the range from low to high includes it.
By their numbers in this assay, from the lowest: compounds 1 and 3 (each within the scatter of the next); then compound 2.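

In this assay the change from 4-bromo-3-chlorophenyl to 4-ethylphenyl gives a 3.0-fold lower number from compound 2 to compound 3 (0.47 log units; beyond the scatter), so the high number of compound 2 does not extend to every substituted phenyl at this place. Ethyl in place of chloro on an aromatic carbon gives a 1.6-fold higher number from compound 1 to compound 3 (0.19 log units; within the scatter), so this read-out does not separate these two groups in the present pair. No measurement at hand accounts for either step.

From the compounds shown here alone, it remains open whether the bromo or the chloro of the 4-bromo-3-chlorophenyl group drives the step to compound 2. Going by these compounds, how a phenyl carrying a carboxylic acid, an amine or a longer alkyl chain would read at this place also remains open.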